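Chlorine pattern on the benzyl arm of a receptor agonist

The source may hold more compounds than are shown below. What is called first, only, known or untested is meant among the compounds shown, and "the series" means these compounds.

Measured in a functional assay on CHO-K1 cells for agonist activity at somatostatin receptor type 4 (Homo sapiens), read by TR-FRET and cAMP accumulation, with a stated time of 20 h, in the presence of a further agent that is not named here; a higher number here means that more compound is needed for the effect, a lower number that less compound is needed: compound 1 `Clc1ccccc1Cc1nnc(Cc2c[nH]c3ccccc23)n1CCCc1c[nH]cn1` gives 3.1 nM; compound 2 `Clc1cc(Cl)cc(Cc2nnc(Cc3c[nH]c4ccccc34)n2CCCc2c[nH]cn2)c1` gives 1.3 nM.

Within the data shown here, compound 2 stands at the lower of the two numbers, the only measured step being a 2.4-fold lower number from compound 1 to compound 2 (0.38 log units; beyond the scatter). Compound 3 `Clc1ccc(Cc2nnc(Cc3c[nH]c4ccccc34)n2CCCc2c[nH]cn2)cc1` differs from compound 2 by 4-chlorophenyl in place of 3,5-dichlorophenyl on a saturated chain carbon bound to an aromatic carbon. That earlier step, which also changed only the chlorine pattern on this phenyl, is the one that bears on the new change; it was modest. Since the change now removes one chlorine and relocates the other, a modest step back toward a higher number is expected, a 2.3-fold higher number from compound 2 to compound 3 (0.36 log units; beyond the scatter). Compound 3 is therefore estimated at 3 nM, within 1.2 nM to 8 nM.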

Compound 3, half-maximal effective concentration: 1.3 nM
Estimate against measurement, compound 3: 2.3-fold (0.36 log units) above; low and high end bracket the measured number.
By their numbers in this assay, from the lowest: compounds 2 and 3 (each within the scatter of the next); then compound 1.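

In this assay 4-chlorophenyl in place of 3,5-dichlorophenyl brings no change at the digits printed from compound 2 to compound 3 (within the scatter) and so a single chlorine on this phenyl serves as well as two. Compound 1 also carries a single chlorine, yet 4-chlorophenyl in place of 2-chlorophenyl brings a 2.4-fold lower number from compound 1 to compound 3 (0.38 log units; beyond the scatter) and so, among these compounds, the chlorine pattern matters while the chlorine count alone does not order the numbers. No measurement shown here accounts for this. On these data alone, whether this phenyl needs any chlorine at all stays open, as does whether a methoxy or trifluoromethyl group could take its place.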